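Chain heteroatom swap on the shared core

The source may hold more compounds than are shown below. What is called first, only, known or untested is meant among the compounds shown, and "the series" means these compounds.

Measured so far:
compound 1 `CC(C)CCn1c(N2CCN(C)CC2)nc2ccccc21`: 1400 nM
compound 2 `CCCCN1CCN(c2nc3ccccc3n2CCOCC)CC1`: 15 nM

In a functional assay on ileum for inhibition of histamine H1 receptor (Cavia porcellus) (a lower number here means a stronger inhibitor, a higher number a weaker inhibitor), compound 1 gives the highest of the two numbers recorded; compound 2 gives 15 nM, a far lower number, and the gap between them lies beyond the scatter. Going by the values given here, no single-point step between measured compounds is available, so the change to compound 3 `CCSCCn1c(N2CCN(C)CC2)nc2ccccc21` has no direct precedent in the set.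

The change from compound 1 to compound 3 is ethylsulfanyl in place of isopropyl on a saturated chain carbon, two bonds along the chain from an aromatic nitrogen. The count of heavy atoms stays the same; a hydrogen-bond acceptor enters the chain.

With only compound 2 at 15 nM showing how far the shared core can reach, the expectation for compound 3 is a lower number than compound 1, of moderate size. The expected step is a 5.6-fold lower number from compound 1 to compound 3 (0.75 log units; beyond the scatter), beyond the scatter but uncertain in size. For compound 3 the estimate in this assay is 250 nM, with a range from 50 nM to 1200 nM.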

Compound 3, half-maximal inhibitory concentration: 19 nM
Compound 3: middle estimate off by 13-fold (1.12 log units), on the high side, and the stated range ends above it.
By their numbers in this assay, from the lowest: compounds 2 and 3 (each within the scatter of the next); then compound 1.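

In this assay, ethylsulfanyl in place of isopropyl on a saturated chain carbon, two bonds along the chain from an aromatic nitrogen, gives a 74-fold lower number from compound 1 to compound 3 (1.87 log units; beyond the scatter) and counts as a large step. This place on the chain is therefore highly sensitive to the swap, even though the count of heavy atoms stays the same and only the branching, the sulfur and the hydrogen-bond acceptor differ. Nothing available bears on why the step is so large.

A single pair cannot separate the contribution of the sulfur from that of the unbranched end of the chain. An all-carbon propyl group in the same place would address that question, and an ethylsulfonyl group would show whether the oxidation state of the sulfur matters.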